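The source may hold more compounds than are shown below. What is called first, only, known or untested is meant among the compounds shown, and "the series" means these compounds.

Half-lives in an in vitro ADME assay on microsomes from liver (Simiiformes); a higher number here means that the compound lasts longer, a lower number that the compound disappears faster:
- compound 1 `Cc1cc(CCCOc2c(C)cc(-c3noc(CF)n3)cc2C)on1`: 0.233 h
- compound 2 `Cc1cc(CCCOc2c(C)cc(-c3noc(C(N)=O)n3)cc2C)on1`: 2.3 h

Compound 2 stands highest of the two measured compounds, and the gap to compound 1 lies beyond the scatter. The next compound, compound 3 `Cc1cc(CCCOc2c(C)cc(-c3noc(C#N)n3)cc2C)on1`, has not yet been measured. Its difference from compound 2 is cyano in place of carbamoyl on an aromatic carbon. In words, cyano takes the place of carbamoyl on an aromatic carbon, while the rest of the structure stays the same.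

Among the measured compounds shown here, only one measured step bears on this change: a 9.9-fold higher number from compound 1 to compound 2 (0.99 log units; beyond the scatter). It is a modest step at the same place and it replaces fluoromethyl with carbamoyl. For the measured compounds named here, no measured compound carries cyano, so this step gives only a loose guide. With the carbamoyl group gone, part of that gain is expected to be lost, which points to a lower number in this assay, smaller in size than the measured step. The expected change is a 2.6-fold lower number from compound 2 to compound 3 (0.41 log units; beyond the scatter).

For compound 3 the estimated half-life is 0.9 h, with an expected range of 0.25 h to 2.8 h.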

Compound 3, half-life: 0.283 h
For compound 3 the middle estimate is 3.2-fold (0.50 log units) above the measured one; the measured number falls inside the stated range.
By their numbers in this assay, from the lowest: compounds 1 and 3 (each within the scatter of the next); then compound 2.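

In this assay, the gain seen with carbamoyl on this aromatic carbon, next to the ring nitrogen and the ring oxygen, does not carry over to cyano, with an 8.1-fold lower number from compound 2 to compound 3 (0.91 log units; beyond the scatter) in the new comparison. Cyano and fluoromethyl at this place are not separated, with a 1.2-fold higher number from compound 1 to compound 3 (0.08 log units; within the scatter) lying within the scatter, so among the three groups shown only carbamoyl stands apart, and a small carbon-linked group with a multiple bond is not enough to hold the higher number. Carbamoyl carries a hydrogen-bond donor and cyano none, but that count is only a structural difference between the two groups, and nothing available here explains the drop in the number.

Still open, as far as these compounds go, is whether the higher number belongs to the whole carbamoyl group or to the amide hydrogen, a question that a dimethylamide, a carboxylic acid or a methyl ester at this place would help to separate. Also open, from the compounds shown here alone, is whether the same ranking of carbamoyl, cyano and fluoromethyl would hold if the three-carbon link or the methyl-bearing rings of the shared core were altered.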